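Working notes: from compound 3 to compound 4

The source may report more compounds than this note shows. Statements on the series, on what has been measured and on what is new or still open speak of the compounds shown alone.

Measured in a functional assay on RAW264.7 cells (Mus musculus) for inhibition, with stated times of 1 h and 24 h; a higher number here means a weaker inhibitor, a lower number a stronger inhibitor:
- compound 1 `COc1cccc(C(=O)Nc2cccc(-c3cc(=O)c4c(OC)c(OC)c(OC)cc4o3)c2)c1` gives "not determined" (no result reported)
- compound 2 `COc1ccccc1C(=O)Nc1ccc(-c2cc(=O)c3c(OC)c(OC)c(OC)cc3o2)cc1` gives 590 nM
- compound 3 `COc1cccc(C(=O)Nc2cccc(-c3cc(=O)c4c(O)c(OC)c(OC)cc4o3)c2)c1` gives "not determined" (no result reported)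

Compound 3 has no single number to stand on, and compound 1 has none either. Only compound 2 carries a value, so the series cannot yet be ranked.

Compound 4 `COc1ccccc1NC(=O)c1cccc(-c2cc(=O)c3c(O)c(OC)c(OC)cc3o2)c1` has the same atoms as compound 3, joined differently: (2-methoxyphenyl)carbamoyl in place of ((3-methoxyphenyl)carbonyl)amino on an aromatic carbon, with (2-methoxyphenyl)carbamoyl in place of ((3-methoxyphenyl)carbonyl)amino on an aromatic carbon.

Among the compounds with values here, no measured step is available as a guide. The change is expected to shift this assay by no more than the usual scatter, in no predictable direction, from the level of compound 2 at 590 nM as the sole anchor. For compound 4 the estimated value is 600 nM, expected to lie between 150 nM and 2500 nM.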

Compound 4, half-maximal inhibitory concentration: 2380 nM
Estimate against measurement, compound 4: 4.0-fold (0.60 log units) below; low and high end bracket the measured number.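

In this assay compound 3 gives "not determined" (no result reported) and compound 4 gives 2380 nM, so no new step can be read between them. The compounds shown leave open how exchanging ((3-methoxyphenyl)carbonyl)amino for (2-methoxyphenyl)carbamoyl affects inhibition. No evidence bears on this result.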